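A few compounds are considered here, and "the series" means these few. Any claim that something is new, unique, unknown or untested is made for them only; others in the source may bear on it.

Of the compounds shown here, three sharing one core have been measured in an ADME assay on a cell-free system (plasma, Homo sapiens); a lower number here means a smaller unbound share, a higher number a larger unbound share of the compound: compound 1 `CCNC(=O)Nc1nc2cc(-c3cccnc3)c(=O)n(C(C)C)c2s1` gives 0.21, compound 2 `CCNC(=O)Nc1nc2cc(-c3cccnc3)c(=O)n(CCC(C)C)c2s1` gives 0.06, and compound 3 `CCNC(=O)Nc1nc2cc(-c3cccnc3)c(=O)n(CC3CCOCC3)c2s1` gives 0.14. Compound 3 lies within the scatter of compound 1 and clearly higher than compound 2. Compound 4 `CCNC(=O)Nc1nc2cc(-c3cccnc3)c(=O)n(C(C)C(=O)O)c2s1` differs from compound 3 as follows: 1-carboxyethyl in place of (oxan-4-yl)methyl on an aromatic nitrogen. In words, 1-carboxyethyl stands in place of (oxan-4-yl)methyl on an aromatic nitrogen. The measured steps at this nitrogen stay small: a 1.5-fold lower number from compound 1 to compound 3 (0.18 log units; within the scatter) lies within the scatter, while a 3.5-fold lower number from compound 1 to compound 2 (0.54 log units; beyond the scatter) and a 2.3-fold higher number from compound 2 to compound 3 (0.37 log units; beyond the scatter) are modest. Within the data shown here, no measured compound carries 1-carboxyethyl, so the direction remains open. The expected step is a 1.1-fold higher number from compound 3 to compound 4 (0.03 log units; within the scatter), none beyond the scatter. In this assay compound 4 is estimated at 0.15, with an expected range from 0.05 to 0.4.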

Compound 4, unbound fraction: 0.22
Compound 4: middle estimate off by 1.5-fold (0.17 log units), on the low side, within the range that was stated.
By their numbers in this assay, from the lowest: compound 2; then compounds 3, 1 and 4 (each within the scatter of the next).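

In this assay, 1-carboxyethyl on this aromatic nitrogen gives no separation from the groups closest to it: a 1.6-fold higher number from compound 3 to compound 4 (0.20 log units; within the scatter) and a 1.0-fold higher number from compound 1 to compound 4 (0.02 log units; within the scatter) both stay within the scatter, so carboxy in place of methyl brings no readable shift here. Isopentyl remains the one group that stands apart, now also against 1-carboxyethyl, with a 3.7-fold higher number from compound 2 to compound 4 (0.56 log units; beyond the scatter), a modest step beyond the scatter. No measured evidence bears on the reason for this. On these data alone, it remains open how an amine, or a carboxylic acid on a longer chain, would read at this nitrogen.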